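The compounds below may be only part of what the source reports. "The series", "measured", "known", "first", "only" and "open" are said of these compounds alone.

Compound 1 `CCc1ccc(Nc2cc(NC(=O)Nc3cc(OC)cc(OC)c3)ncn2)cc1`: 23.5%
Compound 2 `COc1cc(Nc2cc(NC(=O)Nc3c(Cl)cccc3Cl)ncn2)cc(OC)c1`: 55.5%
Compound 3 `COc1cc(NC(=O)Nc2cc(Nc3cc(I)ccc3OC)ncn2)cc(OC)c1`: 55%

All three share one core and were tested in a functional assay on NCI-H520 cells (Homo sapiens) for inhibition, read by MTT assay, with a stated time of 48 h, tested at 10 uM; a higher number here means more inhibition at the concentration tested (going by the name of the read-out), a lower number less inhibition. Compound 2 and compound 3 lie within the usual scatter of each other, and both stand well above compound 1. Compound 4 `COc1cc(Nc2cc(NC(=O)Nc3c(Cl)cccc3Cl)ncn2)cc(C(F)(F)F)c1` differs from compound 2 by trifluoromethyl in place of methoxy on an aromatic carbon. Going by the values given here, the only measured step, a number 31.5 percentage points higher from compound 1 to compound 3 (beyond the scatter), alters a group elsewhere in the molecule, so it does not bear on this change, and no measured pair probes the ring that is changed here. With no guidance pointing either way, compound 4 is expected to stay close to compound 2, with an expected step of a number 5.5 percentage points lower from compound 2 to compound 4 (within the scatter) that lies within the scatter. The estimated value for compound 4 is 50%, with a range from 30% to 70%.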

Compound 4, a percentage reported as inhibition, at one concentration (the size of the read-out at that concentration, not a potency): 23.1%
The estimate for compound 4 lay 26.9 percentage points above the measured number, outside the stated range (below it).
By their numbers in this assay, from the lowest: compounds 4 and 1 (each within the scatter of the next); then compounds 3 and 2 (each within the scatter of the next).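

In this assay, the replacement of one methoxy by trifluoromethyl gives a number 32.4 percentage points lower from compound 2 to compound 4 (beyond the scatter), so this position on the aromatic ring is sensitive to the group it carries. The earlier compounds shown here could not show this, since no measured pair among them changes this ring. Nothing available here explains the drop.

Still open, from the compounds shown here alone, is whether the outcome reflects losing methoxy or gaining trifluoromethyl. A hydroxyl, an amine or a simple methyl at this position could help separate the two, and whether the same swap behaves alike with other groups elsewhere on the shared core is also unknown.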